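The source may hold more compounds than are shown below. What is called first, only, known or untested is meant among the compounds shown, and "the series" means these compounds.

Measured so far:
compound 1, `COc1ccc(CNC(=O)/C=C/c2coc3cc(O)ccc3c2=O)cc1`, 718000 nM
compound 2, `COc1cccc(NC(=O)/C=C/c2coc3cc(OC)ccc3c2=O)c1`, 1130000 nM

In an ADME assay on HepG2 2.2.15 cells (Homo sapiens) for cytotoxicity, read by MTT assay, with stated times of 48 h and 9 days (a higher number here means that more compound is tolerated, a lower number that less compound is tolerated), compound 2 carries the larger of the two numbers, but the gap to compound 1 is within the scatter, so the two are indistinguishable. Compound 3, `COc1ccc2c(=O)c(/C=C/C(=O)Nc3ccccc3OC)coc2c1`, is related to compound 2 by a single rearrangement: 2-methoxyphenyl in place of 3-methoxyphenyl on an amide-type nitrogen. Within the data shown here, no measured step of this kind exists, so nothing in the numbers points to a direction; no step beyond the scatter is expected. For compound 3 in this assay the estimate is 1000000 nM, range 500000 nM to 2000000 nM. The expected step of a 1.1-fold lower number from compound 2 to compound 3 (0.05 log units; within the scatter) is thus essentially flat.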

Compound 3, half-maximal cytotoxic concentration: 1050000 nM
Beside the measured number, compound 3's estimate is 1.1-fold (0.02 log units) below it; measured number inside the range.
By their numbers in this assay, from the lowest: compounds 1, 3 and 2 (each within the scatter of the next).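

In this assay, among these compounds, the change to 2-methoxyphenyl in place of 3-methoxyphenyl on the amide-type nitrogen gives a 1.1-fold lower number from compound 2 to compound 3 (0.03 log units; within the scatter) and is the first one-place comparison. Within this pair, the two methoxyphenyl isomers cannot be told apart in this read-out. No available evidence bears on the reason for this result.

Open, from the compounds shown here alone, is whether a phenyl carrying an amine or a carboxylic acid on that nitrogen would leave the number equally flat. The effect of the hydroxyl on the core of compound 1 also remains unresolved, since compound 1 differs from the others in more than one place.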